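This account rests on a few compounds, and the source may have more. Where it says the series, first, only, none or still open, it means among the compounds named here.

Series values in a functional assay on the whole organism (stomach) for inhibition, with Rattus norvegicus as the target; a lower number here means that less compound is needed, a higher number that more compound is needed for the effect:

- compound 1 `O=C(O)CCC/C=C1\CC2C[C@@H](O)[C@H](/C=C/[C@@H](O)C3Cc4ccccc4C3)C2C1`: 0.0562 mg/kg
- compound 2 `O=C(O)CCC/C=C1\CC2C[C@@H](O)[C@H](/C=C/[C@@H](O)C3Cc4ccc([N+](=O)[O-])cc4C3)C2C1`: 0.14 mg/kg
- compound 3 `CC1([C@H](O)/C=C/[C@@H]2C3C/C(=C/CCCC(=O)O)CC3C[C@H]2O)Cc2ccccc2C1`: 0.0452 mg/kg

Compound 1 stands within the scatter of compound 3 and clearly under compound 2.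

The next analogue, compound 4 `O=C(O)COC/C=C1\CC2C[C@@H](O)[C@H](/C=C/[C@@H](O)C3Cc4ccccc4C3)C2C1`, has no value yet in this assay. It differs from compound 1 by carboxymethoxy in place of 2-carboxyethyl on a saturated chain carbon bound to a double-bonded chain carbon.

Two measured steps start from compound 1. Nitro in place of hydrogen on an aromatic carbon gives a 2.5-fold higher number from compound 1 to compound 2 (0.40 log units; beyond the scatter). Methyl in place of hydrogen on a saturated ring carbon gives a 1.2-fold lower number from compound 1 to compound 3 (0.09 log units; within the scatter). Neither step touches the chain that changes in compound 4, so neither bears directly on this change. They show only how far two single changes elsewhere on compound 1 moved the number. The data hold no measured change in this chain, so no direction can be argued, and no step beyond the scatter is expected. The range is kept wide for the same lack of data.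

The estimated step is a 1.1-fold lower number from compound 1 to compound 4 (0.05 log units; within the scatter).

For compound 4 the expected value is 0.05 mg/kg, with an estimated range from 0.015 mg/kg to 0.17 mg/kg.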

Compound 4, dose for half-maximal effect: 0.0675 mg/kg
For compound 4 the middle estimate is 1.4-fold (0.13 log units) below the measured one; the range from low to high includes it.
By their numbers in this assay, from the lowest: compounds 3, 1 and 4 (each within the scatter of the next); then compound 2.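

In this assay, for the compounds shown here, carboxymethoxy in place of 2-carboxyethyl on a saturated chain carbon bound to a double-bonded chain carbon gives the first reading of a change in this chain (a 1.2-fold higher number from compound 1 to compound 4 (0.08 log units; within the scatter)). The exchange keeps 5 heavy atoms in the group and brings 3 oxygen instead of 2 and 2 hydrogen-bond acceptors instead of 1, and at this place that exchange stays within the scatter, unlike the nitro step on the aromatic carbon (a 2.5-fold higher number from compound 1 to compound 2 (0.40 log units; beyond the scatter)). No measurement on hand explains why the number holds at this place.

From the compounds shown here alone, whether the same place accepts a sulfur atom in the chain in place of the oxygen, a longer chain, or an amide in place of the carboxylic acid stays open, so this single step gives no trend along the chain. Going by these compounds, whether the steps seen with nitro and methyl carry over onto the carboxymethoxy chain also stays open.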